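This account rests on a few compounds, and the source may have more. Where it says the series, first, only, none or still open, it means among the compounds named here.

Compound 1 `Cc1cccc(N2CCN(CC(=O)N(c3ccccc3)c3ccccc3)CC2)c1C` gives the highest number of the three measured compounds in a functional assay on the whole organism (strain Swiss albino) for inhibition, with Mus musculus as the target, with stated times of 10 min, 5 min and 20 min; a lower number here means that less compound is needed, a higher number that more compound is needed for the effect: compound 1 gives 28.5 mg/kg, while compound 2 `O=C(CN1CCN(c2cccc(C(F)(F)F)c2)CC1)N(c1ccccc1)c1ccccc1` gives 21.3 mg/kg and compound 3 `COc1ccccc1N1CCN(CC(=O)N(c2ccccc2)c2ccccc2)CC1` gives 8.2 mg/kg. The step to compound 4 `O=C(CN1CCN(c2ccc([N+](=O)[O-])cc2)CC1)N(c1ccccc1)c1ccccc1` exchanges the group on the ring nitrogen: 4-nitrophenyl in place of 2,3-dimethylphenyl on an amine nitrogen in a ring. Two measured steps exchange a group at the same place: a 1.3-fold lower number from compound 1 to compound 2 (0.13 log units; within the scatter), and a 3.5-fold lower number from compound 1 to compound 3 (0.54 log units; beyond the scatter). For the measured compounds named here, both ran toward lower numbers, one within the scatter and one beyond it, so for compound 4 a modest lowering or no step beyond the scatter is expected, although no measured compound carries the 4-nitrophenyl group itself. Compound 4 is therefore expected near 20 mg/kg, between 8 mg/kg and 45 mg/kg, which would mean an expected step of a 1.4-fold lower number from compound 1 to compound 4 (0.15 log units; within the scatter).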

Compound 4, dose for half-maximal effect: 30 mg/kg
Compound 4: middle estimate off by 1.5-fold (0.18 log units), on the low side, and the stated range covers the measured number.
By their numbers in this assay, from the lowest: compound 3; then compounds 2, 1 and 4 (each within the scatter of the next).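

In this assay the 4-nitrophenyl group stays level with the earlier groups on the amine nitrogen in the ring, with a 1.1-fold higher number from compound 1 to compound 4 (0.02 log units; within the scatter) and with a 1.4-fold higher number from compound 2 to compound 4 (0.15 log units; within the scatter) as well. Against 2-methoxyphenyl it shows a 3.7-fold higher number from compound 3 to compound 4 (0.56 log units; beyond the scatter) and so the lower number does not come with every replacement of 2,3-dimethylphenyl; among the four, compound 3 alone stands apart. Nothing given here explains this difference. Still open, on these data alone, is whether the methoxy group itself or its place on the phenyl ring matters, and whether 4-methoxyphenyl or unsubstituted phenyl would fall with compound 3 or with the others.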